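The source may report more compounds than this note shows. Statements on the series, on what has been measured and on what is new or still open speak of the compounds shown alone.

Measured so far in an assay on isolated protein for inhibition of thyroid hormone receptor beta (Homo sapiens), read by fluorescence, with a stated time of 30 min; a lower number here means a stronger inhibitor, a higher number a weaker inhibitor:
compound 1 `COc1cc(C(=O)N2CCC(O)C(C)C2)cc2nc(NCc3cccc(Cl)n3)oc12` gives 580 nM
compound 2 `COc1cc(C(=O)N2CCC(O)C(C)C2)cc2nc(N[C@H](C)c3cccc(Cl)c3)oc12` gives 48 nM
compound 3 `COc1cc(C(=O)N2CC(C)OCC2CO)cc2nc(N[C@H](C)c3cccc(Cl)c3)oc12` gives 10 nM

Compound 3 stands lowest of the three numbers in this assay; its nearest neighbour is compound 2, and compound 1 lies furthest off. Two steps are on record. The first, a 12-fold lower number from compound 1 to compound 2 (1.08 log units; beyond the scatter), is large and concerns the group on the nitrogen on the aromatic ring. The second, a 4.8-fold lower number from compound 2 to compound 3 (0.68 log units; beyond the scatter), is modest and concerns the group on the carbonyl carbon.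

Compound 4 `COc1cc(C(=O)N2C[C@@H](C)OC[C@H]2CCO)cc2nc(N[C@H](C)c3cccc(Cl)c3)oc12` is not yet measured. It differs from compound 3 in one place: 5-(2-hydroxyethyl)-2-methylmorpholin-4-yl in place of 5-(hydroxymethyl)-2-methylmorpholin-4-yl on a carbonyl carbon. Neither recorded step bears directly on this change. The modest step on the carbonyl carbon exchanged one whole ring for another, whereas here the ring is kept and only the hydroxymethyl chain grows to hydroxyethyl. Among the measured compounds shown here, no step of that kind has been measured, so no step beyond the scatter is expected in this assay. Compound 4 is therefore estimated at 12 nM, with a range from 4 nM to 40 nM. The step this estimate implies, a 1.2-fold higher number from compound 3 to compound 4 (0.08 log units; within the scatter), is expected to remain within the scatter.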

Compound 4, half-maximal inhibitory concentration: 6 nM
The estimate for compound 4 lay 2.0-fold (0.30 log units) above the measured number; the range from low to high includes it.
By their numbers in this assay, from the lowest: compounds 4 and 3 (each within the scatter of the next); then compound 2; then compound 1.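

In this assay, lengthening the hydroxymethyl chain to 2-hydroxyethyl on the 2-methylmorpholin-4-yl group, with the ring kept, gives a 1.7-fold lower number from compound 3 to compound 4 (0.22 log units; within the scatter), so this position shows no separation between these two chain lengths. Replacing 4-hydroxy-3-methylpiperidin-1-yl on the carbonyl carbon gives an 8.0-fold lower number from compound 2 to compound 4 (0.90 log units; beyond the scatter), and with a 4.8-fold lower number from compound 2 to compound 3 (0.68 log units; beyond the scatter) this means both 2-methylmorpholin-4-yl compounds lie beyond the scatter from the piperidine compound. No supporting data are available to explain these results.

Going by these compounds, it remains open whether a longer chain, or an amine or a carboxylic acid in place of the hydroxyl, would stay in the same range. Compound 4 also has 2 defined stereocentres while the structure of compound 3 shows none, so the contribution of the other stereoisomers of the 2-methylmorpholin-4-yl group is unresolved.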